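A few compounds are considered here, and "the series" means these few. Any claim that something is new, unique, unknown or untested is made for them only; others in the source may bear on it.

Measured in a functional assay on the whole organism with Mus musculus as the target; a lower number here means that less compound is needed, a higher number that more compound is needed for the effect:
Compound 1 `CC[C@@H](C(=O)Nc1ccccc1)N1CCCC1=O`: 560 umol/kg
Compound 2 `CCCCCCN(CCCCCC)C(=O)[C@H](CC)N1CCCC1=O`: 560 umol/kg
Compound 3 `CC[C@@H](C(=O)N(C)OC)N1CCCC1=O`: 1000 umol/kg

Compound 3, at 1000 umol/kg, lies within the scatter of both compound 1 and compound 2, so these three values give no ranking. The next compound for this assay is compound 4 `CC[C@@H](C(=O)N(C)O)N1CCCC1=O`, which departs from compound 3 by one change: hydrogen in place of methyl on an oxygen whose other neighbour is an amide-type nitrogen, that is, methoxy to hydroxy (hydrogen in place of methyl on an oxygen).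

Going by the values given here, no two measured compounds differ in only one place, so the series offers no direct precedent for this change. Among the compounds with values here, the only guide is the narrow spread of the values: compound 1 gives 560 umol/kg, and compound 2 gives 560 umol/kg, although their structures differ considerably from each other and from compound 3. On that basis, the step of a 1.3-fold lower number from compound 3 to compound 4 (0.10 log units; within the scatter) is expected to stay within the scatter, with no firm direction. The data do not exclude a larger step, so the expected range is kept wide. For compound 4 the estimated value is 800 umol/kg, with an expected range from 350 umol/kg to 1800 umol/kg.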

Compound 4, dose for half-maximal effect: 1000 umol/kg
Compound 4: middle estimate off by 1.3-fold (0.10 log units), on the low side; the measured number falls inside the stated range.
By their numbers in this assay, from the lowest: compounds 1, 2, 3 and 4 (each within the scatter of the next).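

In this assay, hydrogen in place of methyl on an oxygen whose other neighbours are an amide-type nitrogen, that is, methoxy to hydroxy, gives no change at the digits printed from compound 3 to compound 4 (within the scatter). Going by these compounds alone, this is the first pair that differs in one place, so it is the first direct reading of this position: at this oxygen, within this core and this whole-organism read-out, the methyl can be exchanged for hydrogen without a step that can be told from the scatter. No measurement to hand bears on what lies behind this flat step.

Within the data shown here, the single pair covers only the two smallest ends of what could sit on this oxygen, so whether a longer chain such as ethoxy or a larger group such as benzyloxy would also stay within the scatter remains open. Also open, on these data alone, is whether the flat reading extends to the rest of the hydroxy(methyl)amino group, for example with ethyl in place of the methyl on the nitrogen, or with a carboxylic acid in place of the whole group.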